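Changing the charged ring on a phosphate-bound oxygen

A few compounds are considered here, and "the series" means these few. Any claim that something is new, unique, unknown or untested is made for them only; others in the source may bear on it.

In a functional assay on T47D cells (Homo sapiens) for cytotoxicity, read by MTT assay, with a stated time of 48 h (on this read-out higher numbers stand for weaker inhibition and lower numbers for stronger inhibition), compound 1 (`C[n+]1cccc(OP(=O)([O-])OC[C@H]2O[C@@H](n3cc(F)c(=O)[nH]c3=O)C[C@@H]2OC(=O)c2ccccc2)c1`) gives 3910 nM. Within the data shown here, compound 2 (`O=C(O[C@H]1C[C@H](n2cc(F)c(=O)[nH]c2=O)O[C@@H]1COP(=O)([O-])Oc1ccc[n+](Cc2ccccc2)c1)c1ccccc1`) gives 3430 nM, so compound 1 stands level, within the usual scatter, with the only other measured compound. Compound 3 (`C[N+]1(C)CCC(OP(=O)([O-])OC[C@H]2O[C@@H](n3cc(F)c(=O)[nH]c3=O)C[C@@H]2OC(=O)c2ccccc2)CC1`) keeps the core of compound 1 but carries a different group on an oxygen whose other neighbour is phosphorus: a group of 8 heavy atoms (7 carbon, 1 nitrogen; one six-membered non-aromatic ring with 1 hetero atom) in place of a group of 7 heavy atoms (6 carbon, 1 nitrogen; one six-membered aromatic ring with 1 hetero atom), on an oxygen. Among the measured compounds shown here, the one measured step, a 1.1-fold lower number from compound 1 to compound 2 (0.06 log units; within the scatter), adds a phenyl in place of hydrogen on a saturated chain carbon bound to an aromatic nitrogen. It stays within the scatter, but it leaves the aromatic ring in place, so it is only a weak guide here. For the measured compounds named here, no measured compound carries the non-aromatic ring, so no step beyond the scatter is expected, though with wide uncertainty. The expected change is a 1.1-fold lower number from compound 1 to compound 3 (0.05 log units; within the scatter). Compound 3 is estimated at 3500 nM, with an expected range of 1300 nM to 9500 nM.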

Compound 3, half-maximal inhibitory concentration: 11900 nM
The estimate for compound 3 lay 3.4-fold (0.53 log units) below the measured number; measured number outside the range, above it.
By their numbers in this assay, from the lowest: compounds 2 and 1 (each within the scatter of the next); then compound 3.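

In this assay, this position responds to the change of group, with a 3.0-fold higher number from compound 1 to compound 3 (0.48 log units; beyond the scatter), whereas the phenyl added on the chain carbon in compound 2 gave a step within the scatter. Both groups on the oxygen have a net charge of +1 and one six-membered ring with 1 hetero atom, so sharing these features does not keep the number level. No available evidence explains this step.

The entering group differs in both its non-aromatic ring and its carbon count, so these compounds cannot show which difference goes with the higher number. A piperidine ring with a single methyl on its nitrogen would separate the two, and an open-chain trimethylammonium group would show whether any ring is needed at this oxygen.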